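Solubility of compound 3 after the 5-cyanopentyl chain goes

A few compounds are considered here, and "the series" means these few. Any claim that something is new, unique, unknown or untested is made for them only; others in the source may bear on it.

Measured in a physicochemical assay for solubility, in phosphate buffer, with a stated time of 18 h; on this read-out higher numbers stand for higher solubility and lower numbers for lower solubility:
Compound 1 `Cc1nc(C(C)(C)C)nc2nc(N)c(C#N)c(N)c12`: 37000 nM
Compound 2 `CC(C)(C)c1nc(CCCCCC#N)c2c(N)c(C#N)c(N)nc2n1`: 6000 nM

Of these two compounds, compound 2 stands lowest, and compound 1 is its nearest neighbour. Compound 3 `CC(C)(C)c1nc(C2CCCC2)c2c(N)c(C#N)c(N)nc2n1` carries cyclopentyl in place of 5-cyanopentyl on an aromatic carbon. Among the compounds with values here, one measured step bears on this change, a 6.2-fold lower number from compound 1 to compound 2 (0.79 log units; beyond the scatter). That step involved a different substitution, so it offers only a rough guide to size. A modest move to a higher number in this assay is expected, smaller than that step. The expected step is a 2.2-fold higher number from compound 2 to compound 3 (0.34 log units; beyond the scatter). The estimate for compound 3 is 13000 nM, with an expected range of 4000 nM to 35000 nM.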

Compound 3, solubility: < 1000 nM
Compound 3: a limit, no number; the forecaster's own chance of this, stated with the estimate: 3%; middle value at least 13-fold (1.11 log units) from the limit.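

In this assay, cyclopentyl in place of 5-cyanopentyl on this aromatic carbon gives an at least 6.0-fold lower number from compound 2 to compound 3 (0.77 log units; beyond the scatter), so the ring without a nitrile goes lower than the nitrile-bearing chain, not higher. Cyclopentyl in place of methyl gives an at least 37-fold lower number from compound 1 to compound 3 (1.56 log units; beyond the scatter), a larger step than the one the chain produced. The entry for compound 3 is a limit of the assay and not a number: the limit of < 1000 nM in this assay, at which 1 of the 3 values shown sits.

As far as these compounds go, the actual number for compound 3, and so the full size of both steps, stays open. Also open, from the compounds shown here alone, is how an amine or a carboxylic acid on this aromatic carbon would read.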